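The source may hold more compounds than are shown below. What is called first, only, known or untested is meant among the compounds shown, and "the series" means these compounds.

The measured compounds:

Compound 1, `C=CCOc1ccc(C(=O)/C=C/c2cc(OC)cc(OC)c2)cc1`: 25000 nM
Compound 2, `C=CCOc1ccc(C(=O)/C=C/c2cc(OC)c(OC)c(OC)c2)cc1`: 30000 nM
Compound 3, `COc1ccc(OC)c(/C=C/C(=O)c2ccc(O)cc2)c1`: 22000 nM

In a functional assay (Homo sapiens) for inhibition (a higher number here means a weaker inhibitor, a lower number a stronger inhibitor), compound 1 gives 25000 nM, compound 2 gives 30000 nM and compound 3 gives 22000 nM. All three values lie within the scatter of one another, so no order among them can be drawn. The change from compound 1 to compound 2 is methoxy in place of hydrogen on an aromatic carbon, and the step it made, a 1.2-fold higher number from compound 1 to compound 2 (0.08 log units; within the scatter), is within the scatter.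

Compound 4, `COc1cc(OC)c(OC)cc1/C=C/C(=O)c1ccc(O)cc1`, has not yet been measured in this assay. It differs from compound 3 by methoxy in place of hydrogen on an aromatic carbon. This is the same kind of change as that from compound 1 to compound 2, but not the same: in compound 2 the entering group sits ortho to two methoxy groups and para to a large group, whereas in compound 4 it sits ortho to a methoxy group, meta to a methoxy group and para to a large group. The difference between the cores of compound 1 and compound 3 is not broken down here.

The expectation for compound 4 rests on the one measured occurrence of this kind of change, a 1.2-fold higher number from compound 1 to compound 2 (0.08 log units; within the scatter), which left the value essentially unchanged. The step from compound 3 to compound 4 is therefore estimated as a 1.2-fold higher number from compound 3 to compound 4 (0.09 log units; within the scatter). Compound 4 is expected to give about 27000 nM in this assay, with an estimated range from 12000 nM to 60000 nM.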

Compound 4, half-maximal inhibitory concentration: 28000 nM
The estimate for compound 4 lay 1.0-fold (0.02 log units) below the measured number; the measured number falls inside the stated range.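

In this assay, methoxy in place of hydrogen on an aromatic carbon gave a 1.3-fold higher number from compound 3 to compound 4 (0.10 log units; within the scatter), and this step can be set beside the earlier one on the other core: the same change on two cores in this assay, a 1.2-fold higher number (0.08 log units; within the scatter) from compound 1 to compound 2 and a 1.3-fold higher number (0.10 log units; within the scatter) from compound 3 to compound 4, 1.1-fold (0.03 log units) apart, within the scatter of two such steps. The change thus behaved alike on the two cores, leaving the number within the scatter each time, so these values give no sign that the core of compound 1 and the core of compound 3 respond differently to it. Among the compounds shown here, this does not show that the change would carry over to other cores, as it rests on only two pairs; the entering methoxy also has different surroundings in compound 2 and compound 4, so the two steps do not separate the effect of the core from that of the place, and neither step is large enough to reveal a dependence on either.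

The compounds shown leave open whether another group in place of that hydrogen, such as an amine, a carboxylic acid or a longer chain, would move the number beyond the scatter. For the compounds shown here, they also leave open how each of the differences between the two cores contributes on its own, as no pair here isolates any one of them.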